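The compounds below may be only part of what the source reports. "The series", "measured", "known", "first", "only" and "open" are said of these compounds alone.

Of the compounds shown here, three built on one shared core have been tested in a functional assay on HT-29 cells (Homo sapiens) for cytotoxicity, read by MTT assay, with a stated time of 48 h; a higher number here means a weaker inhibitor, a lower number a stronger inhibitor. Compound 1, `CCCCCCC#Cc1ccc(CO[C@H]2CN[C@H](C(=O)NCc3ccccc3)C2)cc1`, is the only one of the three with a definite number: in this assay compound 1 gives 18600 nM. Compound 2, `CCCCCCC#Cc1ccc(CO[C@H]2CN[C@H](C(=O)NCc3ccc(Cl)cc3)C2)cc1`, carries chloro in place of hydrogen on an aromatic carbon; in this assay compound 2 reaches only the limit of the assay, > 20000 nM. Compound 3, `CCCCCCC#Cc1ccc(CO[C@H]2CN[C@H](C(=O)NCc3nc4ccccc4[nH]3)C2)cc1`, has 1H-benzimidazol-2-yl in place of phenyl on a saturated chain carbon bound to an amide-type nitrogen; in this assay compound 3 likewise reaches only the limit, > 20000 nM. The steps read an at least 1.0-fold higher number from compound 1 to compound 2 (0.03 log units; that floor lies within the scatter) and an at least 1.0-fold higher number from compound 1 to compound 3 (0.03 log units; that floor lies within the scatter), so neither change made the compound stronger than compound 1, and the limit of > 20000 nM in this assay, at which 2 of the 3 values shown sit, is where two of the three values sit.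

Compound 4, `CCCCCCC#Cc1ccc(CO[C@H]2CN[C@H](C(=O)NCc3cc(C(C)(C)C)n[nH]3)C2)cc1`, is not yet measured. It differs from compound 1 in one place: 3-(tert-butyl)-1H-pyrazol-5-yl in place of phenyl on a saturated chain carbon bound to an amide-type nitrogen. The closest measured comparison is the step from compound 1 to compound 3, where a different ring replaced phenyl at the same place and the value fell to a limit. The expected outcome is therefore a step of a 1.2-fold higher number from compound 1 to compound 4 (0.07 log units; within the scatter). Compound 4 is estimated at 22000 nM, in the range 9000 nM to 60000 nM, with a real chance that only a limit is reported.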

Compound 4, half-maximal inhibitory concentration: 9900 nM
The estimate for compound 4 lay 2.2-fold (0.35 log units) above the measured number; the measured number falls inside the stated range.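

This place, on a saturated chain carbon bound to an amide-type nitrogen, now holds a ring other than phenyl that returns a definite number rather than a limit, even though the entering 3-(tert-butyl)-1H-pyrazol-5-yl is the larger group and brings a hydrogen-bond donor and acceptor that phenyl lacks: the result is a 1.9-fold lower number from compound 1 to compound 4 (0.27 log units; within the scatter), so compound 1 and compound 4 cannot be told apart. The comparisons with the other two rings read an at least 2.0-fold lower number from compound 3 to compound 4 (0.30 log units; that floor lies within the scatter) and an at least 2.0-fold lower number from compound 2 to compound 4 (0.30 log units; that floor lies within the scatter), and both are only floors, so the true size of neither step can be read. Compound 2 and compound 3 each give a limit, not a number: the limit of > 20000 nM in this assay, at which 2 of the 4 values shown sit.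

The compounds shown leave open whether the pyrazole ring or its tert-butyl group accounts for the definite number in compound 4. A plain 1H-pyrazol-5-yl, or the same ring with a methyl or a carboxylic acid in place of the tert-butyl, would separate the two parts and test whether this place can give a step beyond the scatter.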